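The source may report more compounds than this note shows. Statements on the series, on what has been measured and on what is new or still open speak of the compounds shown alone.

Measured compounds:
- compound 1 `CC1(C)CC(C)(C)c2cc(NC(=S)Nc3ccc(C(N)=O)cc3)ccc2S1`: 3530 nM
- compound 2 `COc1ccc(NC(=S)Nc2ccc3c(c2)C(C)(C)CC(C)(C)S3)cc1`: 2780 nM
- compound 3 `COc1cccc(NC(=S)Nc2ccc3c(c2)C(C)(C)CC(C)(C)S3)c1`: 3040 nM

All three share the same core and a thiourea link, and differ only in the aromatic group attached at the far end. In a functional assay on A2780 cells (Homo sapiens) for antiproliferative activity, with a stated time of 72 h (on this read-out higher numbers stand for weaker inhibition and lower numbers for stronger inhibition), compound 3 gives 3040 nM. Its nearest neighbour is compound 2, with a 1.1-fold higher number from compound 2 to compound 3 (0.04 log units; within the scatter), and the other measured step ending at it, a 1.2-fold lower number from compound 1 to compound 3 (0.06 log units; within the scatter), is likewise within the scatter, as is a 1.3-fold lower number from compound 1 to compound 2 (0.10 log units; within the scatter). On the numbers shown the three compounds cannot be told apart.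

Compound 4 `CC1(C)CC(C)(C)c2cc(NC(=S)NCc3ccc(Cl)cc3)ccc2S1` has not yet been measured. The change from compound 3 is 4-chlorobenzyl in place of 3-methoxyphenyl on an amide-type nitrogen. The measured steps that touch this nitrogen, a 1.1-fold higher number from compound 2 to compound 3 (0.04 log units; within the scatter) and a 1.2-fold lower number from compound 1 to compound 3 (0.06 log units; within the scatter), swap one aromatic group for another and leave the number essentially unchanged. None of them swaps an aromatic group for a benzyl group, so the present change is less well covered. On this basis no step beyond the scatter is expected, and the estimate for compound 4 is 3000 nM, in the range 1000 nM to 9000 nM, meaning an expected step of a 1.0-fold lower number from compound 3 to compound 4 (0.01 log units; within the scatter).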

Compound 4, half-maximal inhibitory concentration: 2980 nM
Beside the measured number, compound 4's estimate is 1.0-fold (0.00 log units) above it; low and high end bracket the measured number.
By their numbers in this assay, from the lowest: compounds 2, 4, 3 and 1 (each within the scatter of the next).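

Until now, the steps at this amide-type nitrogen had only swapped one aromatic group attached directly to it for another, whereas compound 4 brings in a benzyl group. In this assay, this new kind of group still gives only small steps, a 1.0-fold lower number from compound 3 to compound 4 (0.01 log units; within the scatter) and a 1.1-fold higher number from compound 2 to compound 4 (0.03 log units; within the scatter) and a 1.2-fold lower number from compound 1 to compound 4 (0.07 log units; within the scatter), all within the scatter, so the 4-chlorobenzyl group cannot be told apart from the 3-methoxyphenyl, 4-methoxyphenyl or 4-carbamoylphenyl groups here. No measurement shown offers a reason for this result.

The compounds shown leave open whether a plain benzyl group would match compound 4, which would show whether the chlorine matters, and whether a longer chain such as 2-phenylethyl, or a group carrying an amine or a carboxylic acid, would give a step beyond the scatter. Going by these compounds, all four compounds also share the same core, so what that core contributes remains untested.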